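This account rests on a few compounds, and the source may have more. Where it says the series, first, only, none or still open, it means among the compounds named here.

Compound 2 `O=C(Nc1ccc(Cl)cc1CN1C(=O)c2ccccc2C1=O)c1ccco1` is examined in an assay on CHO cells for positive allosteric modulation of metabotropic glutamate receptor 5 (Rattus norvegicus), read by FLIPR; on this read-out lower numbers stand for an effect already at smaller amounts and higher numbers for an effect only at larger amounts of compound. In this assay compound 2 gives only a limit, < 1000 nM, not a number. Compound 1 `O=C(Nc1ccc(Cl)cc1CN1C(=O)c2ccccc2C1=O)c1cccnn1`, which carries pyridazin-3-yl on the carbonyl carbon in its place, likewise gives only a limit in this assay, < 1000 nM. The step that the two limits leave unreadable from compound 1 to compound 2 therefore cannot be sized, because both readings sit at the limit of < 1000 nM in this assay, at which 2 of the 2 values shown sit. Compound 3 `O=C(Nc1ccc(Cl)cc1CN1C(=O)c2ccccc2C1=O)c1cncs1` has not yet been measured in this assay. It differs from compound 2 by 1,3-thiazol-5-yl in place of furan-2-yl on a carbonyl carbon. For the measured compounds named here, the only measured step on this scaffold is unreadable, so no size or direction of change in this assay can be read from the known compounds for this exchange. The expectation is that compound 3 also reaches the limit, with an estimated step that the limit leaves unreadable from compound 2 to compound 3. Compound 3 is estimated at 300 nM, in a range from 40 nM to 1500 nM.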

Compound 3, half-maximal effective concentration: < 1000 nM
Compound 3: no number, only a limit (the forecaster's own chance of this, stated with the estimate: 70%); the middle value lies beyond the limit too.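

Compound 3 gives only a limit in this assay, as do compound 1 and compound 2, so no step among these three compounds can be read: the limit of < 1000 nM in this assay, at which 3 of the 3 values shown sit.

The compounds shown leave open whether pyridazin-3-yl, furan-2-yl and 1,3-thiazol-5-yl on the carbonyl carbon differ at all in this assay, and by how much.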